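Amide variation on a shared purine-type core, antiproliferative series

The compounds below may be only part of what the source reports. "The series", "measured", "known", "first", "only" and "open" are said of these compounds alone.

Compound 1 `CCCSc1nc(Cl)c2c(n1)N(Cc1ccccc1)C(C(=O)N1CCN(Cc3ccccc3)CC1)N2`: 14400 nM
Compound 2 `CCCSc1nc(Cl)c2c(n1)N(Cc1cccs1)C(C(=O)N1CCN(C)CC1)N2`: 6420 nM
Compound 3 `CCCSc1nc(Cl)c2c(n1)N(Cc1ccccc1)C(C(=O)NCCNC(=O)OC(C)(C)C)N2`: 53200 nM

In a functional assay on A549 cells (Homo sapiens) for antiproliferative activity, read by MTT assay, with a stated time of 72 h (a lower number here means a stronger inhibitor, a higher number a weaker inhibitor), compound 3 gives 53200 nM, the highest of the three numbers. Its nearest neighbour is compound 1, whose value of 14400 nM lies beyond the scatter of compound 3; compound 2, with 6420 nM, lies further still. Compound 3 thus stands as the weakest inhibitor among the measured set.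

Compound 4 `CCCSc1nc(Cl)c2c(n1)N(Cc1ccccc1)C(C(=O)NCCCc1ccccc1)N2` keeps the shared core and the open-chain amide of compound 3 and differs only in the chain terminus: benzyl in place of (tert-butoxycarbonyl)amino on a saturated chain carbon, two bonds along the chain from an amide-type nitrogen. Within the data shown here, no step between two measured compounds isolates this change, so the expectation rests on the remaining data. Compound 1, which also carries a benzyl group on its amide-side substituent, gives 14400 nM, and compound 4 brings a benzyl group onto the open chain in place of the (tert-butoxycarbonyl)amino group.

The step from compound 3 to compound 4 is expected to be a 2.4-fold lower number from compound 3 to compound 4 (0.38 log units; beyond the scatter), a modest move toward a lower number, likely at the edge of the scatter. Compound 4 is estimated at 22000 nM in this assay, with a plausible range from 7000 nM to 70000 nM.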

Compound 4, half-maximal inhibitory concentration: 9430 nM
For compound 4 the middle estimate is 2.3-fold (0.37 log units) above the measured one; the measured number falls inside the stated range.
By their numbers in this assay, from the lowest: compounds 2, 4 and 1 (each within the scatter of the next, the first and the last beyond it); then compound 3.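

In this assay, the terminus of the open-chain amide proves sensitive to substitution: benzyl in place of (tert-butoxycarbonyl)amino on a saturated chain carbon, two bonds along the chain from an amide-type nitrogen, gives a 5.6-fold lower number from compound 3 to compound 4 (0.75 log units; beyond the scatter) with the shared core unchanged. This is the only step among the compounds shown that isolates a single change, and it is the first direct sign that this chain position moves the number beyond the scatter. The change swaps a group with no ring, one hydrogen-bond donor and two hydrogen-bond acceptors for a six-membered aromatic ring of carbon only with neither, but no measurement at hand bears on what lies behind the step.

The compounds shown leave open whether the step tracks the entering aromatic ring or the departure of the (tert-butoxycarbonyl)amino group, which a free amine or a cyclohexyl group at the same place would help separate. Also open, on these data alone, is how the number responds to chain length, which a longer chain ending in phenyl would test against the 3-phenylpropyl group of compound 4.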